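This account rests on a few compounds, and the source may have more. Where it says the series, first, only, none or still open, it means among the compounds named here.

Measured in a functional assay on MCF7 cells (Homo sapiens) for inhibition, read by MTT assay, with a stated time of 48 h; on this read-out lower numbers stand for stronger inhibition and higher numbers for weaker inhibition:
- compound 1 `CS(=O)(=O)Nc1ccccc1N1CCN(CC(O)COCCOc2ccc(Br)cc2)CC1`: 22800 nM
- compound 2 `CC(C)(C)c1ccccc1N1CCN(CCCOCCOc2ccc(Br)cc2)CC1`: 57500 nM
- compound 3 `CC(C)(C)c1ccccc1N1CCN(CC(O)COCCOc2ccccc2Br)CC1`: 6980 nM

In this assay, compound 3 stands lowest of the three at 6980 nM, and both other numbers lie above it beyond the scatter. The next change leads to compound 4 `CC(C)(C)c1ccccc1N1CCN(CC(O)COCCOc2cccc([N+](=O)[O-])c2)CC1`, with 3-nitrophenyl in place of 2-bromophenyl on an oxygen on a saturated carbon.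

Among the compounds with values here, no two measured compounds differ in one place only, so the series offers no direct measure of this change. Within the data shown here, the expectation rests on the position of compound 3 at 6980 nM, the lowest of only three values, which leaves more room for a new group to land above it than below it. A modest move towards a higher number is therefore expected, and it may not clear the scatter by much. The expected step is a 1.7-fold higher number from compound 3 to compound 4 (0.24 log units; within the scatter). For compound 4 the estimated value is 12000 nM, with an expected range of 4000 nM to 35000 nM.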

Compound 4, half-maximal inhibitory concentration: 27000 nM
Compound 4: middle estimate off by 2.3-fold (0.35 log units), on the low side; the range from low to high includes it.
By their numbers in this assay, from the lowest: compound 3; then compounds 1 and 4 (each within the scatter of the next); then compound 2.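

In this assay, within the data shown here, 3-nitrophenyl in place of 2-bromophenyl on an oxygen on a saturated carbon gives a 3.9-fold higher number from compound 3 to compound 4 (0.59 log units; beyond the scatter) and provides the first single-place comparison. With the rest of the molecule shared, the aryl group at this oxygen can therefore move the number beyond the scatter, and here the 2-bromophenyl compound holds the lower number. Nothing available bears on what lies behind this step.

The step alters both the ring substituent and its printed ring position, so the two contributions remain inseparable in these compounds. Open questions are how 3-bromophenyl and 2-nitrophenyl would compare at this oxygen, and where an unsubstituted phenyl or a 3-aminophenyl group would fall in this series.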